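Chloro on the phenol of compound 3

The source may report more compounds than this note shows. Statements on the series, on what has been measured and on what is new or still open speak of the compounds shown alone.

Measured in a functional assay on A549 cells (Homo sapiens) for cytotoxicity, read by MTT assay, with a stated time of 72 h (on this read-out higher numbers stand for weaker inhibition and lower numbers for stronger inhibition), so far:
- compound 1 `COc1ccc(/C=C2\CCC/C(=C\c3ccccc3Br)C2=O)cc1OC` gives > 20000 nM (a limit)
- compound 2 `COc1cccc(/C=C2\CCC/C(=C\c3ccc(OC)c(OC)c3)C2=O)c1` gives 6700 nM
- compound 3 `COc1ccc(/C=C2\CCC/C(=C\c3ccc(O)cc3)C2=O)cc1OC` gives > 20000 nM (a limit)

Compound 3 gives only a limit (> 20000 nM) and no number. Compound 4 `COc1ccc(/C=C2\CCC/C(=C\c3ccc(O)c(Cl)c3)C2=O)cc1OC` differs from it by one change, 4-hydroxyphenyl to 3-chloro-4-hydroxyphenyl: chloro in place of hydrogen on an aromatic carbon. The chloro sits ortho to a hydroxy group.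

Within the data shown here, no measured step adds a chloro. The three available steps each exchange one substituted phenyl for another: an at least 2.9-fold lower number from compound 1 to compound 2 (0.47 log units; beyond the scatter), then an at least 2.9-fold higher number from compound 2 to compound 3 (0.47 log units; beyond the scatter), and finally a step that the two limits leave unreadable from compound 1 to compound 3. They therefore bear on this change only loosely. Compound 2 (6700 nM) shows that a number is reachable in this series. Compound 1, with its 2-bromophenyl, stays at a limit (> 20000 nM), so a halogen offers no assurance.

A modest move to a lower number is expected, though the result may well remain at the limit. The expected change is an at least 1.6-fold lower number from compound 3 to compound 4 (0.22 log units; that floor lies within the scatter) in this assay. Compound 4 is estimated at 12000 nM, with an expected range of 4000 nM to 30000 nM.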

Compound 4, half-maximal inhibitory concentration: > 20000 nM
Compound 4: no number, only a limit (the forecaster's own chance of this, stated with the estimate: 45%); at least 1.6-fold (0.22 log units) between middle value and limit.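

In this assay compound 4 gives > 20000 nM, which is a limit and not a number. Chloro on this aromatic carbon, ortho to a hydroxy group, therefore does not bring the phenol to a measurable value, and the steps that link this compound to compound 3 and compound 1 cannot be read. Among these compounds, the only readable comparison, 3-chloro-4-hydroxyphenyl in place of 3-methoxyphenyl, gives an at least 2.9-fold higher number from compound 2 to compound 4 (0.47 log units; beyond the scatter), so the chlorinated phenol falls on the same side of that gap as the phenol without chloro.

Any effect of the chloro on potency remains hidden in this series: the limit of > 20000 nM in this assay, at which 3 of the 4 values shown sit. Open, going by these compounds, are whether chloro gives a readable step on a compound with a number, such as compound 2, and whether an amine in place of the chloro of compound 4 would give a number.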